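Swapping the Aminophenyl Arm for a Tetrazolyl Phenyl

The source may report more compounds than this note shows. Statements on the series, on what has been measured and on what is new or still open speak of the compounds shown alone.

Compound 1 `CCCS(=O)(=O)Nc1ccc(F)c(C(=O)c2n[nH]c3ncc(-c4ccccc4N)cc23)c1F` carries a 2-aminophenyl group on its shared core. For the measured compounds named here, in an assay for binding affinity to dual specificity mitogen-activated protein kinase kinase 4 (Homo sapiens), read by KINOMEscan, tested at 100 nM (a lower number here means a stronger effect, a higher number a weaker effect of the compound at the concentration tested), compound 1 gives 23%, the second highest of the three numbers measured so far. Compound 2 `CCCS(=O)(=O)Nc1ccc(F)c(C(=O)c2n[nH]c3ncc(-c4ccc(C(C)(C)C)cc4)cc23)c1F`, with a 4-(tert-butyl)phenyl group in the same place, gives 46%, and compound 3 `CCCS(=O)(=O)Nc1ccc(F)c(C(=O)c2n[nH]c3ncc(-c4ccc(S(=O)(=O)NCC)cc4)cc23)c1F`, with a 4-(ethylsulfamoyl)phenyl group, gives 3%. The measured steps run in opposite directions: a number 23 percentage points higher from compound 1 to compound 2 (beyond the scatter), whereas a number 20 percentage points lower from compound 1 to compound 3 (beyond the scatter), and a number 43 percentage points lower from compound 2 to compound 3 (beyond the scatter).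

Compound 4 `CCCS(=O)(=O)Nc1ccc(F)c(C(=O)c2n[nH]c3ncc(-c4ccc(-c5nnn[nH]5)cc4)cc23)c1F` differs from compound 1 in a single place: 4-(1H-tetrazol-5-yl)phenyl in place of 2-aminophenyl on an aromatic carbon. The new group, like the ethylsulfamoyl group of compound 3, brings hydrogen-bond acceptors onto the phenyl ring, so the step from compound 1 to compound 3 is the one that bears most directly on this change, and it was a modest drop. The step to compound 2 shows the other outcome possible at this position, a modest rise. Weighing the closer likeness to compound 3, the change is expected to act as a number 15 percentage points lower from compound 1 to compound 4 (beyond the scatter). Compound 4 is therefore estimated at 8%, with a range from 0% to 25%.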

Compound 4, a percentage reported as activity, at one concentration (the size of the read-out at that concentration, not a potency): 0.15%
Beside the measured number, compound 4's estimate is 7.9 percentage points above it; the measured number falls inside the stated range.
By their numbers in this assay, from the lowest: compounds 4 and 3 (each within the scatter of the next); then compound 1; then compound 2.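

In this assay, compound 4 is a second case where a group carried at the 4 position of the phenyl ring gives a lower number than the 2-aminophenyl group (a number 22.9 percentage points lower from compound 1 to compound 4 (beyond the scatter)), so the drop seen with compound 3 is no longer a lone result. The 1H-tetrazol-5-yl and ethylsulfamoyl end groups differ in their atoms yet cannot be told apart here (a number 2.9 percentage points lower from compound 3 to compound 4 (within the scatter)), whereas replacing tert-butyl with 1H-tetrazol-5-yl matters a great deal (a number 45.9 percentage points lower from compound 2 to compound 4 (beyond the scatter)). These compounds therefore show that the end group on the phenyl ring can set the reading, but no available evidence explains why.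

Going by these compounds, it remains open how a 4-aminophenyl group would read, which would separate the effect of the amine from that of where it sits. A 4-carboxyphenyl group would likewise test how far the tetrazole ring itself is needed.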